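Swapping an Aromatic Ring for a Saturated Amine Ring

The compounds below may be only part of what the source reports. "The series", "measured", "known", "first", "only" and "open" are said of these compounds alone.

Compound 2 `CCC(C)(C)Cc1c[nH]c(CCc2ccc(-c3cnsc3)cc2)n1` holds the lower of the two measured numbers in a functional assay on HEK293 cells for agonist activity at Bombesin receptor subtype-3 (Homo sapiens), read by luminescence and calcium flux, with a stated time of 10 min; a lower number here means that less compound is needed, a higher number that more compound is needed for the effect: compound 2 gives 44 nM, while compound 1 `CCC(C)(C)Cc1c[nH]c(CCc2ccc(-c3cccc(C#N)n3)cc2)n1` gives 193 nM. For the measured compounds named here, the one measured step, a 4.4-fold lower number from compound 1 to compound 2 (0.64 log units; beyond the scatter), exchanges one aromatic group for another on the aromatic carbon of the six-membered ring of carbon only. Compound 3 `CCC(C)(C)Cc1c[nH]c(CCc2ccc(N3CCCCC3)cc2)n1` has not yet been measured in this assay. It differs from compound 2 in a single place: piperidin-1-yl in place of 1,2-thiazol-4-yl on an aromatic carbon. Going by the values given here, the step from compound 1 to compound 2 bears on this change only loosely: it too altered the group on that aromatic carbon, yet it swapped one aromatic ring for another, whereas compound 3 brings in a six-membered non-aromatic ring with one hetero atom, something no measured compound shows. Among the compounds with values here, with one modest step to go on and no example of such a ring, the direction is uncertain; a step of modest size, more likely toward the number of compound 1 than away from it, is expected, a 2.5-fold higher number from compound 2 to compound 3 (0.40 log units; beyond the scatter). Compound 3 is therefore estimated at 110 nM, within a range from 25 nM to 500 nM.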

Compound 3, half-maximal effective concentration: 171 nM
For compound 3 the middle estimate is 1.6-fold (0.19 log units) below the measured one; measured number inside the range.
By their numbers in this assay, from the lowest: compound 2; then compounds 3 and 1 (each within the scatter of the next).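

In this assay, the position on an aromatic carbon para to a large group proves able to hold a non-aromatic ring, and compound 3 keeps agonist activity with piperidin-1-yl there, although the change carries a 3.9-fold higher number from compound 2 to compound 3 (0.59 log units; beyond the scatter). The aromatic character of the group does not by itself sort these three compounds: with a 1.1-fold lower number from compound 1 to compound 3 (0.05 log units; within the scatter), the piperidin-1-yl of compound 3 cannot be told apart from the aromatic 6-cyanopyridin-2-yl of compound 1, which goes against any reading that aromatic rings give the lower number, and only the 1,2-thiazol-4-yl of compound 2 stands apart from the other two groups. Nothing available accounts for this separation or ties it to any feature of the groups.

Going by these compounds, it remains open whether the number of compound 3 would hold for other saturated amine rings, such as pyrrolidine or morpholine, or for an open-chain dimethylamino group. On these data alone, it is equally open whether the low number of compound 2 belongs to the 1,2-thiazol-4-yl alone or extends to related five-membered aromatic rings such as thiophene or thiazole.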